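Ring swap at the saturated ring carbon: compound 4

The compounds below may be only part of what the source reports. "The series", "measured", "known", "first", "only" and "open" are said of these compounds alone.

Measured so far:
compound 1 `CCCOC(=O)C1=C(C)NC(=O)NC1c1ccco1` 3%
compound 2 `CCCC(=O)C1=C(C)NC(=O)NC1c1ccco1` 1%
compound 3 `CC1=C(C(=O)CC(C)C)C(c2ccco2)NC(=O)N1` 31%

In an assay on membranes from HeLa cells for displacement of a labelled ligand from adenosine receptor A3 (Homo sapiens), read by scintillation counting, with a stated time of 180 min, tested at 1 uM (a lower number here means less inhibition, a higher number more inhibition at the concentration tested (going by the name of the read-out)), compound 2 gives the lowest of the three numbers. The nearest neighbour lies within the scatter: a number 2 percentage points lower from compound 1 to compound 2 (within the scatter). The furthest lies beyond it: a number 30 percentage points higher from compound 2 to compound 3 (beyond the scatter). Compound 4 `CCCC(=O)C1=C(C)NC(=O)NC1c1ccsc1` keeps the propylcarbonyl group of compound 2 and changes only the aromatic ring: thiophen-3-yl in place of furan-2-yl on a saturated ring carbon. Going by the values given here, none of the measured steps touches this ring; all three concern the group on the carbonyl carbon, so nothing measured bears directly on the swap. With no guidance, the step of a number 4 percentage points higher from compound 2 to compound 4 (within the scatter) is expected to stay within the scatter. Compound 4 is therefore estimated at 5%, between 0% and 25%.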

Compound 4, a percentage reported as inhibition, at one concentration (the size of the read-out at that concentration, not a potency): 1%
Compound 4: the middle estimate sits 4 percentage points above what was measured; the range from low to high includes it.
By their numbers in this assay, from the lowest: compounds 2, 4 and 1 (each within the scatter of the next); then compound 3.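

In this assay, going by these compounds alone, the step of no change at the digits printed from compound 2 to compound 4 (within the scatter) is the first reading of a change at the saturated ring carbon rather than on the carbonyl carbon. Within the data shown here, with the propylcarbonyl group held, thiophen-3-yl and furan-2-yl are not told apart here, so the only steps beyond the scatter remain those on the carbonyl carbon. Nothing at hand bears on why the two rings read alike.

Still open, going by these compounds, is whether this swap stays within the scatter with the isobutyl carbonyl group of compound 3. Also open, on these data alone, is how a phenyl group or an amine-bearing ring would read on this carbon.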